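This account rests on a few compounds, and the source may have more. Where it says the series, first, only, none or still open, it means among the compounds named here.

The compounds here share one core, differing in two side groups: the group on the nitrogen attached to the aromatic ring and the group on the amide-type nitrogen. Compound 1 `Nc1ccc(Nc2c(C(=O)NCc3ccc(F)cc3)nc(Br)c3cccnc23)cc1` and compound 3 `NCCNc1c(C(=O)NCc2ccc(F)cc2)nc(Br)c2cccnc12` carry the same amide group and differ only in the first place. In a functional assay on MCF7 cells (Homo sapiens) for cytotoxicity, read by MTT assay, with a stated time of 72 h (on this read-out higher numbers stand for weaker inhibition and lower numbers for stronger inhibition), compound 1 gives 4000 nM, and compound 3 gives 6000 nM; the change from one to the other is a 1.5-fold higher number from compound 1 to compound 3 (0.18 log units; within the scatter), so the two values are not distinguishable.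

In this assay compound 2 `N[C@H]1CC[C@H](Nc2c(C(=O)NCc3ccco3)nc(Br)c3cccnc23)CC1` gives "not determined" (no result reported): no result was reported for it, so it stands nowhere on the scale set by compounds 1 and 3. Compound 4 `N[C@H]1CC[C@H](Nc2c(C(=O)NC3CCCCC3)nc(Br)c3cccnc23)CC1` differs from compound 2 by one change on the amide-type nitrogen: cyclohexyl in place of (furan-2-yl)methyl on an amide-type nitrogen.

No measured pair shows this change, so nothing tells how large a step it may cause or in which direction. Among the compounds with values here, the only measured step, from compound 1 to compound 3, concerns a different place and was within the scatter. The expectation for compound 4 therefore rests on the values of compounds 1 and 3 alone, with a wide range. Compound 4 is estimated at 5000 nM, within 1500 nM to 16000 nM.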

Compound 4, half-maximal inhibitory concentration: 5200 nM
Compound 4: middle estimate off by 1.0-fold (0.02 log units), on the low side; the range from low to high includes it.
By their numbers in this assay, from the lowest: compounds 1, 4 and 3 (each within the scatter of the next).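

Compound 2 has no number in this assay to set against compound 4, so no step can be read between these two compounds. No other information on these compounds helps to explain the result. The compounds shown leave open whether cyclohexyl in place of (furan-2-yl)methyl on an amide-type nitrogen changes the number in this assay at all.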